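The compounds below may be only part of what the source reports. "The series", "measured", "known", "first", "only" and "open" are said of these compounds alone.

Measured compounds:
compound 1 `Cc1ccc(NC(=O)Nc2cccc(CNc3ncnc4ccccc34)c2)cc1`, 24900 nM
compound 2 `COc1cc2ncnc(NCc3cccc(NC(=O)Nc4ccccc4)c3)c2cc1OC`, 17100 nM

Of the compounds shown here, two have been measured in a functional assay on A549 cells (Homo sapiens) for antiproliferative activity, read by MTT assay; a lower number here means a stronger inhibitor, a higher number a weaker inhibitor. Compound 1 `Cc1ccc(NC(=O)Nc2cccc(CNc3ncnc4ccccc34)c2)cc1` gives 24900 nM in this assay, and compound 2 `COc1cc2ncnc(NCc3cccc(NC(=O)Nc4ccccc4)c3)c2cc1OC` gives 17100 nM. These two numbers sit within the usual scatter of each other, so neither compound can be set apart from the other on this evidence; compound 2 simply stands beside compound 1 at the weak end of the range.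

Compound 3 `COc1cc2ncnc(NCc3cccc(NC(=O)Nc4cccc(C(F)(F)F)c4)c3)c2cc1OC` has not yet been measured. It differs from compound 2 by the change (trifluoromethyl in place of hydrogen on an aromatic carbon), a trifluoromethyl in place of hydrogen on an aromatic carbon of the phenyl that ends the urea. Within the data shown here, no pair of measured compounds shows the effect of this change, so the expectation for it rests on the general size of such steps rather than on a measured precedent. A step from compound 2 of about a 1.9-fold lower number from compound 2 to compound 3 (0.28 log units; within the scatter) is expected, toward a stronger inhibitor but only modestly so. Compound 3 is therefore estimated at 9000 nM in this assay, with a range from 3000 nM to 30000 nM.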

Compound 3, half-maximal inhibitory concentration: 35300 nM
Compound 3: middle estimate off by 3.9-fold (0.59 log units), on the low side; measured number outside the range, above it.
By their numbers in this assay, from the lowest: compounds 2, 1 and 3 (each within the scatter of the next, the first and the last beyond it).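

In this assay, trifluoromethyl in place of hydrogen on an aromatic carbon of the phenyl that ends the urea brings a 2.1-fold higher number from compound 2 to compound 3 (0.31 log units; beyond the scatter), a modest move toward a weaker inhibitor and the first step shown at this position. Among these compounds, until now the end of the urea had no measured step of its own, and this one shows that a trifluoromethyl meta to a large group on that ring does not strengthen compound 2 in this read-out but weakens it slightly, so 3-(trifluoromethyl)phenyl is no gain over phenyl here. As this is a single step on a single core, it describes this pair alone and sets no trend for the position, and nothing measured alongside these numbers speaks to why the value moved.

As far as these compounds go, what remains open is whether the loss belongs to trifluoromethyl itself or to any substituent at this place, which a chlorine, an amine or a carboxylic acid on the same carbon would help to separate. From the compounds shown here alone, it is also open whether trifluoromethyl would bring a step of similar size and direction on the core of compound 1, or at another carbon of the same ring.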